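Replacing a branched alkyl with a trifluoromethylphenyl group

The source may report more compounds than this note shows. Statements on the series, on what has been measured and on what is new or still open speak of the compounds shown alone.

Compound 1 `COc1cccc(CNCCCNc2ccnc3cc(-c4ccc(C(C)(C)C)cc4)ccc23)c1O` gives 9.47 in a physicochemical assay for acid dissociation.
Compound 2 `COc1ccc(Oc2ccc3c(NCCCNCc4cccc(OC)c4O)ccnc3c2)cc1` gives 9.28 in this assay.
Compound 3 `CCC(CC)c1ccc2c(NCCCNCc3cccc(OC)c3O)ccnc2c1` gives 9.47 in this assay.

Compound 3 stands level with compound 1 at the digits shown; the step of a number 0.19 log units higher from compound 2 to compound 3 (within the scatter) likewise stays within the scatter, so all three numbers sit within the usual scatter. Compound 4 `COc1cccc(CNCCCNc2ccnc3cc(-c4ccc(C(F)(F)F)cc4)ccc23)c1O` differs from compound 3 by 4-(trifluoromethyl)phenyl in place of pentan-3-yl on an aromatic carbon. The step that bears on this, no change at the digits printed from compound 1 to compound 3 (within the scatter), swapped the same pentan-3-yl for a different aryl group without moving the number, and a number 0.19 log units higher from compound 2 to compound 3 (within the scatter) also stayed within the scatter. No step beyond the scatter is therefore expected in this assay. Compound 4 is expected to give 9.42, with a range from 9.1 to 9.75. The expected step, a number 0.05 log units lower from compound 3 to compound 4 (within the scatter), lies within the scatter.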

Compound 4, acid dissociation constant: 9.47
Compound 4: middle estimate off by 0.05 log units, on the low side; the measured number falls inside the stated range.
By their numbers in this assay, from the lowest: compounds 2, 1, 3 and 4 (each within the scatter of the next).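

At this position, on an aromatic carbon of the shared core, this assay does not separate a ring-free pentan-3-yl from a 4-(trifluoromethyl)phenyl group (no change at the digits printed from compound 3 to compound 4 (within the scatter)). Within the aryl series, trifluoromethyl in place of tert-butyl gives no change at the digits printed from compound 1 to compound 4 (within the scatter) on the same phenyl ring. Against the 4-methoxyphenoxy compound, the result is a number 0.19 log units higher from compound 2 to compound 4 (within the scatter) as well, so this position has yet to yield a step beyond the scatter.

Nothing here explains this flat result. From the compounds shown here alone, whether an amine or a carboxylic acid at this position would also stay within the scatter remains open.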